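Methoxy Groups on a Sulfonamide Scaffold in Colon Cancer Cells

The source may hold more compounds than are shown below. What is called first, only, known or untested is meant among the compounds shown, and "the series" means these compounds.

Compound 1 `COc1ccccc1-c1ccc(S(=O)(=O)N2CCC(N3CCC(C)CC3)CC2)cc1`: 26 nM
Compound 2 `CC1CCN(C2CCN(S(=O)(=O)c3ccc(-c4ccccc4)cc3)CC2)CC1`: 258 nM
Compound 3 `COc1cccc(S(=O)(=O)N2CCC(N3CCC(C)CC3)CC2)c1`: > 5000 nM

Of the compounds shown here, three have been measured in a functional assay on DLD-1 cells (Homo sapiens) for antiproliferative activity, read by CellTiter-Glo, with a stated time of 72 h; on this read-out higher numbers stand for weaker inhibition and lower numbers for stronger inhibition. Compound 2 gives 258 nM. Compound 1, which differs from it by methoxy in place of hydrogen on an aromatic carbon, gives 26 nM, a step of a 9.9-fold lower number from compound 2 to compound 1 (1.00 log units; beyond the scatter). For compound 3 this assay reports only a limit, > 5000 nM, one of the values sitting at the limit of > 5000 nM in this assay, at which 1 of the 3 values shown sits. The difference between the core of compound 3 and the core of compound 2 is not broken down here.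

Compound 4 `COc1ccc(S(=O)(=O)N2CCC(N3CCC(C)CC3)CC2)cc1OC` is not yet measured. It differs from compound 3 by methoxy in place of hydrogen on an aromatic carbon. This is the same kind of change as from compound 2 to compound 1, but the surroundings differ: there the new group sat ortho to a large group, here it sits ortho to a methoxy group and para to a large group. For compound 4 the expected step is an at least 1.6-fold lower number from compound 3 to compound 4 (0.22 log units; that floor lies within the scatter), resting on compound 3 giving only the limit > 5000 nM. Compound 4 is therefore expected to give about 3000 nM, likely from 800 nM to 10000 nM.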

Compound 4, half-maximal inhibitory concentration: 138 nM
Compound 4: the middle estimate sits 22-fold (1.34 log units) above what was measured; the measured number lies below the stated range.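

In this assay methoxy in place of hydrogen on the core of compound 3 gives an at least 36-fold lower number from compound 3 to compound 4 (1.55 log units; beyond the scatter). The change lowers the number on both cores, so its direction carries over, but its size does not: the same change on two cores in this assay, a 9.9-fold lower number (1.00 log units; beyond the scatter) from compound 2 to compound 1 and an at least 36-fold lower number (1.55 log units; beyond the scatter) from compound 3 to compound 4, at least 3.6-fold (0.56 log units) apart, beyond the scatter of two such steps. On these data alone, compound 3 gives only a limit of the assay at > 5000 nM and so the true size of its step remains unknown, while two cores cannot show how the change behaves on others.

As far as these compounds go, it remains open how much depends on where the methoxy group sits on the aromatic ring. From the compounds shown here alone, it is also open whether an ethoxy group or an amine in that place would lower the number too.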